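Replacing chloro with benzyl(methyl)amino on compound 1

The compounds below may be only part of what the source reports. "The series", "measured", "known", "first", "only" and "open" are said of these compounds alone.

In an ADME assay on J774.1 cells (Mus musculus) for cytotoxicity, read by resazurin assay, with a stated time of 48 h (a lower number here means a stronger inhibitor, a higher number a weaker inhibitor), compound 1 `CCCCn1cc(C(=O)O)c(=O)c2cc(F)c(Cl)cc21` gives > 100000 nM as a limit of the assay and not as a number. Compound 2 `CCCn1cc(C(=O)O)c(=O)c2cc(F)c(Cl)cc21` gives > 100000 nM as a limit too. Compound 3 `CCCCn1cc(C(=O)NCc2ccc(OC)c([N+](=O)[O-])c2)c(=O)c2cc(F)c(N3CCC(C(N)=O)CC3)cc21` likewise gives > 100000 nM as a limit. The whole set thus stands at the limit of > 100000 nM in this assay, at which 3 of the 3 values shown sit, and offers no true number to build on. Among the compounds with values here, the only measured step, a step that the two limits leave unreadable from compound 1 to compound 2, gives no size to carry forward.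

Compound 4 `CCCCn1cc(C(=O)O)c(=O)c2cc(F)c(N(C)Cc3ccccc3)cc21` departs from compound 1 by benzyl(methyl)amino in place of chloro on an aromatic carbon and carries benzyl(methyl)amino in place of chloro on an aromatic carbon, ortho to a fluoro group. Within the data shown here, no measured step covers this change, so the expectation is only weakly grounded. In this assay a modest move toward a lower number is expected, and the result may well stay at the limit. The estimated step is an at least 1.2-fold lower number from compound 1 to compound 4 (0.09 log units; that floor lies within the scatter) and remains uncertain. For compound 4 the estimate is 80000 nM as an expected value, with an expected range from 25000 nM to 100000 nM in this measurement.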

Compound 4, half-maximal inhibitory concentration: 43200 nM
For compound 4 the middle estimate is 1.9-fold (0.27 log units) above the measured one, within the range that was stated.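

In this assay, within the data shown here, benzyl(methyl)amino in place of chloro on an aromatic carbon, ortho to a fluoro group, gives an at least 2.3-fold lower number from compound 1 to compound 4 (0.36 log units; beyond the scatter), the first readable step in the set and one that lies beyond the scatter. From the compounds shown here alone, the true size of this step remains open, as it starts from a limit of the assay and the printed size is only a floor. This aromatic carbon is thus the first place in the set where a change yields a real number, and compound 4 alone gives one, the others staying at the limit: the limit of > 100000 nM in this assay, at which 3 of the 4 values shown sit.

What the compounds shown leave open is how much of the step belongs to the benzyl ring and how much to the amine nitrogen, which a dimethylamino or morpholine group on the same aromatic carbon would help to separate. Going by these compounds, whether a methoxybenzyl group in place of the benzyl group would move the number further also remains open.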